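The source may report more compounds than this note shows. Statements on the series, on what has been measured and on what is new or still open speak of the compounds shown alone.

Measured compounds:
Compound 1, `Cn1c(=O)c(S(=O)(=O)Cc2ccc(F)cc2)cc2cnc(Nc3ccc4[nH]ccc4c3)nc21`, gives 30000 nM in a functional assay on K562 cells (Homo sapiens) for inhibition, read by trypan blue exclusion, with a stated time of 72 h; on this read-out lower numbers stand for stronger inhibition and higher numbers for weaker inhibition.
Compound 2, `Cc1ccc(S(=O)(=O)c2cc3cnc(Nc4ccc5[nH]ccc5c4)nc3n(C)c2=O)cc1`, gives 750 nM in this assay.
Compound 3, `Cn1c(=O)c(S(=O)(=O)Nc2ccc(F)cc2F)cc2cnc(Nc3ccc4[nH]ccc4c3)nc21`, gives 5000 nM in this assay.

Compound 2 stands lowest of the three numbers. Its nearest neighbour is compound 3, reached by a 6.7-fold higher number from compound 2 to compound 3 (0.82 log units; beyond the scatter); its furthest is compound 1, from which it is reached by a 40-fold lower number from compound 1 to compound 2 (1.60 log units; beyond the scatter). The third step, a 6.0-fold lower number from compound 1 to compound 3 (0.78 log units; beyond the scatter), also lies beyond the scatter. All three measured steps exchange the group on the sulfonyl sulfur; the two-ring system on the aromatic nitrogen is the same in compound 1, compound 2 and compound 3.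

Compound 4, `Cc1ccc(S(=O)(=O)c2cc3cnc(Nc4cnc5[nH]ccc5c4)nc3n(C)c2=O)cc1`, keeps the sulfonyl substituent of compound 2 and differs from it only at that shared ring system: a group of 9 heavy atoms (7 carbon, 2 nitrogen; one five-membered aromatic ring with 1 hetero atom, one six-membered aromatic ring with 1 hetero atom) in place of a group of 9 heavy atoms (8 carbon, 1 nitrogen; one five-membered aromatic ring with 1 hetero atom, one six-membered aromatic ring of carbon only), on a nitrogen on an aromatic ring. For the measured compounds named here, no measured step touches this position, so the measured steps give no direct guide to its size. The change preserves ring count, heavy-atom count and the single donor, adding one acceptor. Without a precedent, the expectation for compound 4 is a number close to that of compound 2, with a step of no change at the digits printed from compound 2 to compound 4 (within the scatter) in this assay, not beyond the scatter. Compound 4 is therefore estimated at 750 nM, with a range from 250 nM to 2500 nM.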

Compound 4, half-maximal inhibitory concentration: 15000 nM
Compound 4: middle estimate off by 20-fold (1.30 log units), on the low side; measured number above the stated range.
By their numbers in this assay, from the lowest: compound 2; then compound 3; then compounds 4 and 1 (each within the scatter of the next).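

For the compounds shown here, the two-ring system on the aromatic nitrogen, which no earlier step had touched, proves to be a sensitive position in this assay. With the 4-methylphenyl group on the sulfonyl sulfur held constant, exchanging 1H-indol-5-yl for a group of the same heavy-atom count, whose six-membered aromatic ring carries 1 hetero atom, gives a 20-fold higher number from compound 2 to compound 4 (1.30 log units; beyond the scatter), so this single change weakens inhibition by a large step, the same size class as the largest change at the sulfonyl sulfur, a 40-fold lower number from compound 1 to compound 2 (1.60 log units; beyond the scatter). Nothing available explains why this exchange has so large an effect.

The compounds shown offer only this one pair at the position, so it remains open whether the same exchange would cost as much alongside the 4-fluorobenzyl group of compound 1 or the (2,4-difluorophenyl)amino group of compound 3. As far as these compounds go, it also remains open how inhibition in this assay would respond to a ring system bearing a substituent such as an amine, a methoxy group or a carboxylic acid at this position.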